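Chloro for Hydrogen on Two Related Cores

The compounds below may be only part of what the source reports. "The series", "measured", "known", "first", "only" and "open" are said of these compounds alone.

Compound 1 `ClCc1cccc(Cn2cnc3c(Cl)ncnc32)c1` and compound 2 `ClCc1cccc(Cn2cnc3c(Cl)nc(Cl)nc32)c1` share one core. In a functional assay on ACHN cells (Homo sapiens) for cytotoxicity, read by sulforhodamine B assay, with a stated time of 48 h (a higher number here means a weaker inhibitor of growth, a lower number a stronger inhibitor of growth), compound 1 gives 2080 nM and compound 2 gives 1900 nM. The change between them is chloro in place of hydrogen on an aromatic carbon, and the step it made was a 1.1-fold lower number from compound 1 to compound 2 (0.04 log units; within the scatter). Compound 3 `ClCc1ccccc1Cn1cnc2ncnc(Cl)c21` has the same atoms as compound 1 joined differently; the difference between the two cores is not broken down here. In this assay compound 3 gives 1990 nM, a number that sits with those of compound 1 and compound 2 within the scatter. Compound 4 `ClCc1ccccc1Cn1cnc2nc(Cl)nc(Cl)c21` has not yet been measured in this assay. It arises from compound 3 by chloro in place of hydrogen on an aromatic carbon, the same change as that seen between compound 1 and compound 2, occurring twice among these compounds. Because the same change earlier gave a 1.1-fold lower number from compound 1 to compound 2 (0.04 log units; within the scatter), the step to compound 4 is expected to be small, a 1.1-fold lower number from compound 3 to compound 4 (0.03 log units; within the scatter). Compound 4 is therefore estimated at 1850 nM, with a likely range from 900 nM to 3800 nM.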

Compound 4, concentration for 50% growth inhibition: 350 nM
Compound 4: middle estimate off by 5.3-fold (0.72 log units), on the high side, outside the stated range (below it).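

In this assay, chloro in place of hydrogen on an aromatic carbon gave a 5.7-fold lower number from compound 3 to compound 4 (0.75 log units; beyond the scatter), so on the core of compound 3 the change moved the number beyond the scatter, which it had not done on the core of compound 1. The change therefore did not carry over unaltered from one core to the other, and the two steps stand clearly apart: the same change on two cores in this assay, a 1.1-fold lower number (0.04 log units; within the scatter) from compound 1 to compound 2 and a 5.7-fold lower number (0.75 log units; beyond the scatter) from compound 3 to compound 4, 5.2-fold (0.72 log units) apart, beyond the scatter of two such steps. This shows that the step on one core was a poor guide to the step on the other, but it does not show what in the two cores separates them, and two pairs give no rule for any further core.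

The compounds shown leave open whether an amine or a bromo group, placed between two ring nitrogen atoms, would follow the step on the core of compound 3 or the one on the core of compound 1. They also leave open whether the gap between the two cores would hold in other cell lines.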